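Phenyl for Propyl on the Shared Core

A few compounds are considered here, and "the series" means these few. Any claim that something is new, unique, unknown or untested is made for them only; others in the source may bear on it.

Compound 1, `CCCc1ccc(-c2c(C)[nH]c(=O)n2C)cc1`: 21500 nM in a functional assay on brain (Rattus norvegicus, strain Wistar) for inhibition; a higher number here means a weaker inhibitor, a lower number a stronger inhibitor
Compound 2, `CCCc1ccc(-c2c(C)[nH]c(=O)n2C2CCCCC2)cc1`: 13900 nM in this assay
Compound 3, `CCCCCCCCCCc1ccc(-c2c(C)[nH]c(=O)n2C2CCCCC2)cc1`: 27000 nM in this assay

Compound 2 gives the lowest of the three numbers, yet the others stand close to it: the step of a 1.5-fold lower number from compound 1 to compound 2 (0.19 log units; within the scatter) and the step of a 1.9-fold higher number from compound 2 to compound 3 (0.29 log units; within the scatter) both lie within the scatter, so none of the three can be called the strongest inhibitor. Compound 4, `Cc1[nH]c(=O)n(C2CCCCC2)c1-c1ccc(-c2ccccc2)cc1`, differs from compound 2 in one place: phenyl in place of propyl on an aromatic carbon. Going by the values given here, no measured step exchanges a chain for an aromatic ring here, so the guidance is indirect. The closest bearing is a 1.9-fold higher number from compound 2 to compound 3 (0.29 log units; within the scatter), in which a much longer chain entering the same part of compound 2 changed the number only within the scatter, and a 1.5-fold lower number from compound 1 to compound 2 (0.19 log units; within the scatter), in which a saturated ring entering on the aromatic nitrogen did the same. The account therefore expects no step beyond the scatter in this assay, an estimated 1.1-fold higher number from compound 2 to compound 4 (0.03 log units; within the scatter). Compound 4 is estimated at 15000 nM, with a range from 5000 nM to 45000 nM.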

Compound 4, half-maximal inhibitory concentration: 10900 nM
Beside the measured number, compound 4's estimate is 1.4-fold (0.14 log units) above it; measured number inside the range.
By their numbers in this assay, from the lowest: compounds 4, 2, 1 and 3 (each within the scatter of the next, the first and the last beyond it).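

Exchanging propyl for phenyl on the aromatic carbon, para to a large group, gives in this assay a 1.3-fold lower number from compound 2 to compound 4 (0.11 log units; within the scatter) and so adds a six-membered aromatic ring of carbon only. Until now this place had carried only saturated chains, and it now also accepts an aromatic ring with no step beyond the scatter, so the chain and the ring cannot be told apart here. No accompanying measurement bears on this result.

The compounds shown leave open whether a pyridine ring, a cyclohexyl ring, an amine or a carboxylic acid at this place would produce a step beyond the scatter. They also leave open whether phenyl would give a similar number with methyl rather than cyclohexyl on the aromatic nitrogen.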